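The compounds below may be only part of what the source reports. "The series", "measured", "known", "first", "only" and "open" are said of these compounds alone.

Compound 1 `CC(C)(N)CCC(=O)N[C@@H]1CCc2ccccc2N(Cc2ccc(-c3ccccc3-c3nn[nH]n3)cc2)C1=O`: 3 uM
Compound 2 `NCCC(=O)N[C@@H]1CCc2ccccc2N(Cc2ccc(-c3ccccc3-c3nn[nH]n3)cc2)C1=O`: 2 uM
Compound 3 `CC[C@@H](N)C(=O)N[C@@H]1CCc2ccccc2N(Cc2ccc(-c3ccccc3-c3nn[nH]n3)cc2)C1=O`: 0.3 uM

These three share one core and differ only in the amine-bearing chain on the amide carbonyl carbon. In a functional assay on cells (Pituitary gland cell) with growth hormone secretagogue receptor type 1 (Rattus norvegicus) as the target (a lower number here means that less compound is needed, a higher number that more compound is needed for the effect), compound 3 gives 0.3 uM, the lowest of the three numbers; the nearest neighbour is a 6.7-fold lower number from compound 2 to compound 3 (0.82 log units; beyond the scatter) and the furthest is a 10-fold lower number from compound 1 to compound 3 (1.00 log units; beyond the scatter). The step of a 1.5-fold lower number from compound 1 to compound 2 (0.18 log units; within the scatter) concerns a different place on the chain and stays within the scatter. Compound 4 `CC(C)(N)C(=O)N[C@@H]1CCc2ccccc2N(Cc2ccc(-c3ccccc3-c3nn[nH]n3)cc2)C1=O` carries the next change: 1-amino-1-methylethyl in place of 1-aminopropyl on a carbonyl carbon. The two steps ending in compound 3 bear on this place and both lowered the number beyond the scatter, but the new change keeps the same atoms, only joined differently, so for compound 4 a step within the scatter is expected, a 1.5-fold lower number from compound 3 to compound 4 (0.18 log units; within the scatter). Compound 4 is therefore estimated at 0.2 uM, with a likely range from 0.05 uM to 1 uM.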

Compound 4, concentration for half-maximal effect: 0.03 uM
Compound 4: the middle estimate sits 6.7-fold (0.82 log units) above what was measured, outside the stated range (below it).
By their numbers in this assay, from the lowest: compound 4; then compound 3; then compounds 2 and 1 (each within the scatter of the next).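

In this assay, the same atoms joined differently on this carbonyl carbon give a clear change: 1-amino-1-methylethyl in place of 1-aminopropyl brings a 10-fold lower number from compound 3 to compound 4 (1.00 log units; beyond the scatter) and no defined stereocentre remains in that group. Matching atom and donor counts therefore do not make these two groups interchangeable here. The larger steps, a 67-fold lower number from compound 2 to compound 4 (1.82 log units; beyond the scatter) and a 100-fold lower number from compound 1 to compound 4 (2.00 log units; beyond the scatter), leave compound 4 lowest of the four. Still open, from the compounds shown here alone, is whether 1-aminocyclopropyl or the longer 1-amino-1-methylpropyl would keep so low a number. No measurement offered here explains the difference.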